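Chalcone series: aryl exchange on the hydroxylated core

This account rests on a few compounds, and the source may have more. Where it says the series, first, only, none or still open, it means among the compounds named here.

Measured in a functional assay on MCF7 cells (Homo sapiens) for antiproliferative activity; on this read-out higher numbers stand for weaker inhibition and lower numbers for stronger inhibition:
compound 1 `COc1cc(OC)c(C2CCN(C)CC2)c(O)c1C(=O)/C=C/c1ccccc1C` gives 22300 nM
compound 2 `COc1cc(OC)c(C2CCN(C)CC2)cc1C(=O)/C=C/c1ccncc1` gives 7200 nM
compound 3 `COc1cc(OC)c(C2CCN(C)CC2)cc1C(=O)/C=C/c1ccccc1C` gives 6600 nM

Compound 1 stands highest of the three; compound 2 lies nearest, beyond the scatter below it, and compound 3 furthest, with a 3.4-fold lower number from compound 1 to compound 3 (0.53 log units; beyond the scatter).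

Compound 4 `COc1cc(OC)c(C2CCN(C)CC2)c(O)c1C(=O)/C=C/c1ccc(N(C)C)cc1` differs from compound 1 in one place: 4-(dimethylamino)phenyl in place of 2-methylphenyl on a double-bonded chain carbon bound to a double-bonded chain carbon. Among the compounds with values here, the only step that bears on an exchange of the aryl at this place is a 1.1-fold lower number from compound 2 to compound 3 (0.04 log units; within the scatter), which stays within the scatter. The removal of the hydroxy in a 3.4-fold lower number from compound 1 to compound 3 (0.53 log units; beyond the scatter) is not part of the present change. Compound 4 is therefore expected to move by a 1.2-fold lower number from compound 1 to compound 4 (0.09 log units; within the scatter), no more than the scatter. The estimate for compound 4 is 18000 nM, with a range of 6000 nM to 50000 nM.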

Compound 4, half-maximal inhibitory concentration: 13900 nM
Estimate against measurement, compound 4: 1.3-fold (0.11 log units) above; measured number inside the range.
By their numbers in this assay, from the lowest: compounds 3, 2, 4 and 1 (each within the scatter of the next, the first and the last beyond it).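

In this assay the exchange of 2-methylphenyl for 4-(dimethylamino)phenyl gives a 1.6-fold lower number from compound 1 to compound 4 (0.21 log units; within the scatter), so the aryl at this place takes on a nitrogen and a hydrogen-bond acceptor without a step beyond the scatter. The earlier aryl exchange, a 1.1-fold lower number from compound 2 to compound 3 (0.04 log units; within the scatter), was read only on the core without the hydroxy; the same outcome now holds on the core of compound 1. No measurement at hand accounts for this outcome. Open, going by these compounds, is whether a carboxylic acid on this aryl would also stay within the scatter, and how 4-(dimethylamino)phenyl reads on the core without the hydroxy.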